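Swapping the Aryl Group on the Shared Core of Compound 1

The compounds below may be only part of what the source reports. "The series", "measured", "known", "first", "only" and "open" are said of these compounds alone.

Compound 1 `C#Cc1cccc(Nc2ncnc3sc(NC(=O)/C=C/c4ccccc4)cc23)c1` was tested in a functional assay on PC-3 cells (Homo sapiens) for antiproliferative activity, read by MTT assay, with a stated time of 48 h (on this read-out lower numbers stand for stronger inhibition and higher numbers for weaker inhibition), where compound 1 gives 400 nM. Among the three compounds measured, this is the second highest number. Compound 2 `N#Cc1cccc(Nc2ncnc3cc(NC(=O)/C=C/c4ccccc4)sc23)c1` gives 540 nM, a value within the scatter of that of compound 1. Compound 3 `COc1ccc(/C=C/C(=O)Nc2cc3ncnc(Nc4ccc(F)c(Cl)c4)c3s2)cc1` gives 100 nM, a number lower than that of compound 1 by more than the scatter. Compound 4 `O=C(/C=C/c1ccccc1)Nc1cc2c(Nc3ccc(Cl)c(Cl)c3)ncnc2s1` has not been measured; it differs from compound 1 in one place: 3,4-dichlorophenyl in place of 3-ethynylphenyl on a nitrogen on an aromatic ring. Among the compounds with values here, no pair of measured compounds differs in a single place, so no measured step guides this change directly. In this assay the expected step is a 1.6-fold lower number from compound 1 to compound 4 (0.20 log units; within the scatter), a modest move toward a lower number. Compound 4 is estimated at 250 nM, between 100 nM and 600 nM.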

Compound 4, half-maximal inhibitory concentration: 480 nM
Compound 4: middle estimate off by 1.9-fold (0.28 log units), on the low side; the measured number falls inside the stated range.
By their numbers in this assay, from the lowest: compound 3; then compounds 1, 4 and 2 (each within the scatter of the next).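

The swap of 3-ethynylphenyl for 3,4-dichlorophenyl on the nitrogen gives a 1.2-fold higher number from compound 1 to compound 4 (0.08 log units; within the scatter) in this assay. On the shared core of compound 1, this position therefore holds either aryl group without a difference that this read-out can resolve, although the triple bond is gone and two chlorines have entered. No measurement shown explains why the two groups read alike. On these data alone, it remains open whether an aryl group carrying an amine or a carboxylic acid on that nitrogen would also read alike, and whether an unsubstituted phenyl would do so.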